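Hemolysis limits and the hydroxy analogue of compound 3

The compounds below may be only part of what the source reports. "The series", "measured", "known", "first", "only" and "open" are said of these compounds alone.

Measured in a toxicity assay on cells (Erythrocyte, Mus musculus) for activation, read by spectrophotometry and hemolysis, with a stated time of 30 min (a higher number here means that more compound is needed for the effect, a lower number that less compound is needed), each value a limit:
Compound 1 `Oc1ccc(/C=N/Nc2nc3ccccc3s2)cc1O`: > 200 ug/mL
Compound 2 `CN(C)c1ccc(/C=N/Nc2nc3ccccc3s2)cc1`: > 200 ug/mL
Compound 3 `Brc1ccc(/C=N/Nc2nc3ccccc3s2)cc1`: > 200 ug/mL

Compound 3 has no number in this assay, only the limit > 200 ug/mL. Compound 4 `Oc1ccc(/C=N/Nc2nc3ccccc3s2)cc1` has hydroxy in place of bromo on an aromatic carbon, para to a large group: hydroxy in place of bromo on an aromatic carbon. Within the data shown here, the one measured step that bears on this, a step that the two limits leave unreadable from compound 2 to compound 3, has no readable size, and the whole series stands at the limit of > 200 ug/mL in this assay, at which 3 of the 3 values shown sit. Compound 1, which also carries hydroxy, gives the limit > 200 ug/mL. No step beyond the scatter is therefore expected in this assay, and no direction can be given. The estimated step is a step that the limit leaves unreadable from compound 3 to compound 4. For compound 4 the estimated value is 250 ug/mL, with an expected range of 120 ug/mL to 500 ug/mL.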

Compound 4, half-maximal effective concentration: > 200 ug/mL
Compound 4 gave a limit, no number; the forecaster's own chance of this, stated with the estimate: 85%; the middle value lies beyond the limit too.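

In this assay, among these compounds, compound 4 also gave only a limit, so no step from compound 1, compound 2 or compound 3 to compound 4 can be read: the limit of > 200 ug/mL in this assay, at which 4 of the 4 values shown sit. The compounds shown leave open at what concentration any of them would cause hemolysis.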